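This account rests on a few compounds, and the source may have more. Where it says the series, first, only, none or still open, it means among the compounds named here.

Values in an ADME assay on SH-SY5Y cells (Homo sapiens) for cytotoxicity, read by sulforhodamine B assay, with a stated time of 72 h; a lower number here means a stronger inhibitor, a higher number a weaker inhibitor:
- compound 1 `O=C(Nc1nccs1)C1CCN(Cc2ccccc2)CC1`: 76600 nM
- compound 2 `O=C(NCc1cccnc1)C1CCN(Cc2ccccc2)CC1`: > 100000 nM

Compound 2 gives > 100000 nM, which is a limit of the assay and not a number. The same limit is noted in the limit of > 100000 nM in this assay, at which 1 of the 2 values shown sits. Compound 3 `O=C(NCc1ccncc1)C1CCN(Cc2ccccc2)CC1` differs from compound 2 as follows: pyridin-4-yl in place of pyridin-3-yl on a saturated chain carbon bound to an amide-type nitrogen. This places pyridin-4-yl in place of pyridin-3-yl on a saturated chain carbon bound to an amide-type nitrogen. Among the measured compounds shown here, the only measured step, an at least 1.3-fold higher number from compound 1 to compound 2 (0.11 log units; that floor lies within the scatter), involves a different exchange and gives no size to carry over. No step beyond the scatter is expected in this assay, in either direction, and the expected step is a number no higher from compound 2 to compound 3 (the limit leaves the size open). For compound 3 the estimate is 100000 nM, with an expected range of 55000 nM to 180000 nM.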

Compound 3, half-maximal inhibitory concentration: 3370 nM
Compound 3: the middle estimate sits 30-fold (1.47 log units) above what was measured, outside the stated range (below it).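

In this assay, pyridin-4-yl in place of pyridin-3-yl on a saturated chain carbon bound to an amide-type nitrogen gives an at least 29-fold lower number from compound 2 to compound 3 (1.47 log units; beyond the scatter), so this position responds to a change that leaves the counted atoms the same. Compound 2 gives > 100000 nM, a limit of the assay and not a number, so that step is only a floor: the limit of > 100000 nM in this assay, at which 1 of the 3 values shown sits. Exchanging 1,3-thiazol-2-yl for (pyridin-4-yl)methyl on an amide-type nitrogen gives a 23-fold lower number from compound 1 to compound 3 (1.36 log units; beyond the scatter).

Open, on these data alone, is whether pyridin-2-yl, plain phenyl or a longer chain carrying pyridin-4-yl would also give a low number in this assay.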